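The compounds below may be only part of what the source reports. "The series", "measured", "known", "first", "only" and "open" are said of these compounds alone.

Measured compounds:
- compound 1, `OC[C@H]1O[C@@H](n2cnc3c(NCc4ccccc4Cl)ncnc32)[C@H](O)[C@@H]1O` — in a functional assay on G-361 cells (Homo sapiens) for antiproliferative activity, with a stated time of 72 h (on this read-out higher numbers stand for weaker inhibition and lower numbers for stronger inhibition), compound 1 gives "not determined" (no result reported)
- compound 2, `OC[C@H]1O[C@@H](n2cnc3c(NCc4ccc(Cl)c(Cl)c4)ncnc32)[C@H](O)[C@@H]1O` — in this assay compound 2 gives 145000 nM
- compound 3, `COc1ccc(CNc2ncnc3c2ncn3[C@@H]2O[C@H](CO)[C@@H](O)[C@H]2O)c(OC)c1` — in this assay compound 3 gives "not determined" (no result reported)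

Compound 1 therefore stands without a number of its own in this assay; a second member of the series, compound 3, is in the same position, and only compound 2 carries a value, which is weak. For the measured compounds named here, no pair of measured compounds differing in one place exists, so no step size is known from the data.

The unmeasured compound 4, `OC[C@H]1O[C@@H](n2cnc3c(NCc4cccc(O)c4O)ncnc32)[C@H](O)[C@@H]1O`, is reached from compound 1 by 2,3-dihydroxyphenyl in place of 2-chlorophenyl on a saturated chain carbon bound to a nitrogen on an aromatic ring. Going by the values given here, with no value for compound 1 and no measured step anywhere, the direction and size of the change from compound 1 to compound 4 in this assay cannot be read from the numbers; the only anchor is the weak value of compound 2. Compound 4 is expected to land near that anchor, at an estimated 60000 nM, in a range of 10000 nM to 300000 nM.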

Compound 4, half-maximal inhibitory concentration: 16900 nM
Compound 4: the middle estimate sits 3.6-fold (0.55 log units) above what was measured; the range from low to high includes it.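

In this assay, for the compounds shown here, the first readable step at this position, on a saturated chain carbon bound to a nitrogen on an aromatic ring, shows that the aryl group can shift the read-out: 2,3-dihydroxyphenyl in place of 3,4-dichlorophenyl gives an 8.6-fold lower number from compound 2 to compound 4 (0.93 log units; beyond the scatter). Going by these compounds alone, a phenyl ring bearing two hydroxyl groups and no chlorine is therefore tolerated here and gives the lower number of the two, although only this one pair supports the comparison. No accompanying data bear on the reason for this shift.

Steps involving compound 1 or compound 3 cannot be read, as neither has a single value. Also open, from the compounds shown here alone, is whether both hydroxyl groups are needed, and how a single hydroxyl, a methoxy group, an amine or a carboxylic acid on this ring would compare.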